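A Bulkier Acyl Group on a Shared Core

A few compounds are considered here, and "the series" means these few. Any claim that something is new, unique, unknown or untested is made for them only; others in the source may bear on it.

Compound 3 `CCCCC(=O)N1CCN(c2nc(=O)c3cc(C(F)(F)F)cc([N+](=O)[O-])c3s2)CC1` stands in an ADME assay on Vero cells (Chlorocebus sabaeus) for cytotoxicity, read by MTT assay, with a stated time of 72 h (a lower number here means that less compound is tolerated, a higher number that more compound is tolerated), only at a limit of the assay: compound 3 gives > 125000 nM. Compound 1 `CSCC(=O)N1CCN(c2nc(=O)c3cc(C(F)(F)F)cc([N+](=O)[O-])c3s2)CC1` likewise gives only a limit, > 125000 nM. Compound 2 `CCC(C)C(=O)N1CCN(c2nc(=O)c3cc(C(F)(F)F)cc([N+](=O)[O-])c3s2)CC1` also gives only a limit, > 125000 nM. The steps a step that the two limits leave unreadable from compound 1 to compound 3 and a step that the two limits leave unreadable from compound 2 to compound 3 thus cannot be read, since the limit of > 125000 nM in this assay, at which 3 of the 3 values shown sit, holds for every value shown. Compound 4 `CC(C)(C)C1CCC(C(=O)N2CCN(c3nc(=O)c4cc(C(F)(F)F)cc([N+](=O)[O-])c4s3)CC2)CC1` differs from compound 3 by 4-(tert-butyl)cyclohexyl in place of butyl on a carbonyl carbon. No measured step bears readably on this change, so no direction or size of step in this assay can be drawn from the numbers shown. Compound 4 is therefore estimated at 125000 nM, within a range from 50000 nM to 250000 nM. The expected step is a number no higher from compound 3 to compound 4 (the limit leaves the size open).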

Compound 4, half-maximal cytotoxic concentration: > 125000 nM
Compound 4 ended at the assay's limit; the forecaster's own chance of this, stated with the estimate: 60%; the middle value lies on the limit itself.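

For the compounds shown here, no step to compound 4 from compound 1, compound 2 or compound 3 can be read, since all four compounds give only a limit: the limit of > 125000 nM in this assay, at which 4 of the 4 values shown sit. Going by these compounds, whether changing the acyl group alters the result in this assay stays open.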